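The source may hold more compounds than are shown below. What is called first, only, known or untested is meant among the compounds shown, and "the series" means these compounds.

Three compounds of the series have results in a functional assay on BMMC cells (Mus musculus, strain C57BL/6) for inhibition, with stated times of 5 days and 48 h; on this read-out higher numbers stand for weaker inhibition and lower numbers for stronger inhibition. Compound 1 `C=C1CC[C@@H]2[C@](C)(CO)[C@H](O)CC[C@@]2(C)[C@@H]1C/C=C1\C=COC1=O` gives 2770 nM. Compound 2 `C=C1CC[C@@H]2[C@](C)(CO)[C@H](O)CC[C@@]2(C)[C@@H]1C/C=C(/C(=O)O)[C@H](O)CO` returns only a limit, > 30000 nM, as noted in the limit of > 30000 nM in this assay, at which 1 of the 3 values shown sits. Compound 3 `C=C1CC[C@@H]2[C@](C)(CNCc3cccc(OC)c3)[C@H](O)CC[C@@]2(C)[C@@H]1/C=C/C1=CCOC1=O` gives 780 nM, the lower of the two numbers, with compound 1 standing beyond the scatter above it. Compound 4 `C=C1CC[C@@H]2[C@](C)(CNCc3ccc(Br)cc3)[C@H](O)CC[C@@]2(C)[C@@H]1/C=C/C1=CCOC1=O` is not yet measured. It differs from compound 3 by 4-bromophenyl in place of 3-methoxyphenyl on a saturated chain carbon bound to an amine nitrogen. Among the measured compounds shown here, no measured pair carries this change, so its size is open; the expectation is a step within the scatter, with no clear direction. For compound 4 the expected value in this assay is 750 nM, within a range of 250 nM to 2200 nM. The expected step of a 1.0-fold lower number from compound 3 to compound 4 (0.02 log units; within the scatter) is accordingly small.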

Compound 4, half-maximal inhibitory concentration: 430 nM
Beside the measured number, compound 4's estimate is 1.7-fold (0.24 log units) above it; low and high end bracket the measured number.
By their numbers in this assay, from the lowest: compounds 4 and 3 (each within the scatter of the next); then compound 1. At a limit, above all of these: compound 2.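

In this assay, among the compounds shown here, 4-bromophenyl in place of 3-methoxyphenyl on a saturated chain carbon bound to an amine nitrogen gives a first reading at this position (a 1.8-fold lower number from compound 3 to compound 4 (0.26 log units; within the scatter)). This position therefore accepts either aryl group with no readable difference between compound 3 and compound 4. No measurement shown bears on the reason for this step.

The exchange alters the substituent and its ring position together, and 3-bromophenyl or 4-methoxyphenyl would separate the two. On these data alone, an unsubstituted phenyl or a pyridine ring at this position also remains open.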